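This account rests on a few compounds, and the source may have more. Where it says the series, first, only, none or still open, it means among the compounds named here.

Compound 2 `COc1cc(N(CC2CC2)c2ccc(F)c3ccccc23)cnc1C(=O)[C@H]1C[C@@H]1C(=O)O` and compound 1 `COc1cc(N(CC2CC2)c2ccc(Cl)c3ccccc23)cnc1C(=O)[C@H]1C[C@@H]1C(=O)O` share one core and differ only at one aromatic carbon, where compound 2 carries fluoro and compound 1 chloro. In an assay on isolated protein for inhibition of leukotriene C4 synthase (Homo sapiens), read by LC-MS, with stated times of 45 min and 20 min (a higher number here means a weaker inhibitor, a lower number a stronger inhibitor), compound 1 gives 9.41 nM and compound 2 gives 26.5 nM, so compound 2 has the higher of the two numbers, and the step of a 2.8-fold higher number from compound 1 to compound 2 (0.45 log units; beyond the scatter) is modest but beyond the scatter. Compound 3 `CCN(c1cnc(C(=O)[C@H]2C[C@@H]2C(=O)O)c(OC)c1)c1ccc(F)c2ccccc12` keeps the fluoro of compound 2 and changes a different part: methyl in place of cyclopropyl on a saturated chain carbon bound to a nitrogen on an aromatic ring, so that cyclopropylmethyl becomes ethyl. Among the measured compounds shown here, neither measured number touches this chain, so the two values shown give no direct guide to its effect, and the one change that was measured, at the aromatic carbon, moved the number only modestly. The number for compound 3 is therefore expected somewhat higher than that of compound 2, with a range wide enough for a step in either direction, a 1.7-fold higher number from compound 2 to compound 3 (0.23 log units; within the scatter). Compound 3 is estimated at 45 nM, between 15 nM and 150 nM.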

Compound 3, half-maximal inhibitory concentration: 16.8 nM
For compound 3 the middle estimate is 2.7-fold (0.43 log units) above the measured one; the range from low to high includes it.
By their numbers in this assay, from the lowest: compounds 1, 3 and 2 (each within the scatter of the next, the first and the last beyond it).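

In this assay, among the compounds shown here, this is the first look at the chain on the nitrogen, and a 1.6-fold lower number from compound 2 to compound 3 (0.20 log units; within the scatter) stays within the scatter, so compound 2 and compound 3 cannot be told apart. Cutting cyclopropylmethyl back to ethyl removes the three-membered ring, yet the number stays in the same range, so with fluoro on the aromatic carbon, that ring is not needed for inhibition at this level. No measurement shown here offers an explanation for this result.

Still open, as far as these compounds go, is how a longer chain such as butyl, or a chain ending in an amine or a hydroxyl group, would read at this position. Also open, from the compounds shown here alone, is whether ethyl would give a similar number when paired with chloro instead of fluoro on the aromatic carbon.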